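The source may hold more compounds than are shown below. What is called first, only, known or untested is meant among the compounds shown, and "the series" means these compounds.

Measured compounds in an assay on CHO cells for displacement of a labelled ligand from adenosine receptor A3 (Homo sapiens), read by scintillation counting, tested at 1 uM; on this read-out lower numbers stand for less inhibition and higher numbers for more inhibition at the one concentration tested (going by the name of the read-out):
compound 1 `CCc1nc(N)c2nn(-c3ccccc3)cc2n1` gives 38%;
compound 2 `CC(C)Cc1nc(N)c2nn(-c3ccccc3)cc2n1` gives 13%;
compound 3 `CC(C)c1nc(N)c2nn(-c3ccccc3)cc2n1` gives 11%.

Compound 2 holds the second highest of the three numbers. Its nearest neighbour is compound 3, the step of a number 2 percentage points lower from compound 2 to compound 3 (within the scatter) lying within the scatter, while the furthest is compound 1, separated from it by a number 25 percentage points lower from compound 1 to compound 2 (beyond the scatter). The unmeasured compound 4 `COc1ccc(Cc2nc(N)c3nn(-c4ccccc4)cc3n2)cc1` carries 4-methoxyphenyl in place of isopropyl on a saturated chain carbon bound to an aromatic carbon. Within the data shown here, two measured steps bear on a change at this saturated chain carbon bound to an aromatic carbon: a number 25 percentage points lower from compound 1 to compound 2 (beyond the scatter) and a number 27 percentage points lower from compound 1 to compound 3 (beyond the scatter), each a modest fall, whereas a number 2 percentage points lower from compound 2 to compound 3 (within the scatter) shows no difference between isobutyl and isopropyl. The 4-methoxyphenyl of compound 4 is a further variation at the same position, and nothing among the three measured compounds points to a recovery of the number seen for compound 1. In this assay a step of a number 3 percentage points lower from compound 2 to compound 4 (within the scatter) is expected, which would stay within the scatter. Compound 4 is therefore estimated at 10%, with a range from 0% to 30%.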

Compound 4, a percentage reported as inhibition, at one concentration (the size of the read-out at that concentration, not a potency): 38%
For compound 4 the middle estimate is 28 percentage points below the measured one, outside the stated range (above it).
By their numbers in this assay, from the lowest: compounds 3 and 2 (each within the scatter of the next); then compounds 1 and 4 (each within the scatter of the next).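

In this assay, the exchange of isopropyl for 4-methoxyphenyl on a saturated chain carbon bound to an aromatic carbon gives a number 25 percentage points higher from compound 2 to compound 4 (beyond the scatter), so the low numbers of the branched compounds do not extend to every larger group at this position. Against the methyl of compound 1, the same group gives no change at the digits printed from compound 1 to compound 4 (within the scatter), so with an aromatic ring and more heavy atoms in this place the number stays level with that seen with methyl, at the one concentration tested. No available evidence explains why 4-methoxyphenyl and isopropyl part in this way.

The compounds shown do not separate the contribution of the aromatic ring from that of its methoxy oxygen, so how a plain phenyl would read here remains open. Also open, as far as these compounds go, is how a longer straight chain or an amine at this carbon would read.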